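The source may report more compounds than this note shows. Statements on the series, on what has been measured and on what is new or still open speak of the compounds shown alone.

Working notes on the sulfonyl aryl series. In a physicochemical assay for solubility, read by chemiluminescence, measured as kinetic solubility (on this read-out higher numbers stand for higher solubility and lower numbers for lower solubility), compound 1 (`COc1cccc2c1c(NS(=O)(=O)c1ccc(Cl)c(Cl)c1)nn2Cc1cccc(CNC(=O)C(C)(C)O)c1`) gives 76 ug/mL and compound 3 (`COc1cccc2c1c(NS(=O)(=O)c1cccc(Cl)c1Cl)nn2Cc1cccc(CNC(=O)C(C)(C)O)c1`) gives 157 ug/mL. Compound 2 (`COc1cccc2c1c(NS(=O)(=O)c1cccc(Cl)c1)nn2Cc1cccc(CNC(=O)C(C)(C)O)c1`) reads >= 198 ug/mL, which is a limit of the assay and not a number. From the compounds shown here alone, compound 3 therefore has the higher of the two actual numbers, but its order against compound 2 stays open: an at least 1.2-fold lower number from compound 2 to compound 3 (0.10 log units; that floor lies within the scatter).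

Compound 4 (`COc1cccc2c1c(NS(=O)(=O)c1ccc(C)c(F)c1)nn2Cc1cccc(CNC(=O)C(C)(C)O)c1`) has 3-fluoro-4-methylphenyl in place of 2,3-dichlorophenyl on a sulfonyl sulfur. The total of heavy atoms in the group does not change, but one chlorine gives way to a fluorine and the other to a carbon. The closest measured change is a 2.1-fold higher number from compound 1 to compound 3 (0.32 log units; beyond the scatter), which also replaces one group on the sulfonyl sulfur with another. Also relevant is the loss of a chloro, an at least 2.6-fold higher number from compound 1 to compound 2 (0.41 log units; beyond the scatter). Among the measured compounds shown here, no measured step introduces fluoro or methyl, so these precedents give only a rough guide.

Compound 4 is read as closer to compound 1 than to compound 3 in the arrangement of its substituents, so a modest move to a lower number is expected in this assay, no larger than the swap between compound 1 and compound 3. The expected step is a 1.7-fold lower number from compound 3 to compound 4 (0.22 log units; within the scatter). For compound 4 the estimated value is 95 ug/mL, with an expected range of 45 ug/mL to 190 ug/mL.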

Compound 4, solubility: 36 ug/mL
For compound 4 the middle estimate is 2.6-fold (0.42 log units) above the measured one; measured number outside the range, below it.
By their numbers in this assay, from the lowest: compound 4; then compound 1; then compound 3. At a limit, above all of these: compound 2.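

With 3-fluoro-4-methylphenyl on the sulfonyl sulfur, this assay gives a 4.4-fold lower number from compound 3 to compound 4 (0.64 log units; beyond the scatter) against 2,3-dichlorophenyl and a 2.1-fold lower number from compound 1 to compound 4 (0.32 log units; beyond the scatter) against 3,4-dichlorophenyl, so this position can move the number beyond the scatter in the downward direction from both dichlorophenyl compounds. The leaving and entering groups in the first of these steps have the same count of heavy atoms, the same single aromatic ring and no hydrogen-bond donors or acceptors, so those counts do not separate compound 3 from compound 4, and a group without chlorine does not by itself go with a higher number here. Against 3-chlorophenyl the reading is an at least 5.5-fold lower number from compound 2 to compound 4 (0.74 log units; beyond the scatter), which is only a floor, as the value of compound 2 is a limit and not a number: the limit of >= 198 ug/mL in this assay, at which 1 of the 4 values shown sits.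

Fluoro and methyl enter together in compound 4, so the share of each in these steps stays open, as does the order of compound 2 against compound 3. From the compounds shown here alone, how an amine or a carboxylic acid on this aryl group would read in this assay also stays open.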